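Swapping the End Group of a Hydroxy Compound

The compounds below may be only part of what the source reports. "The series", "measured", "known", "first", "only" and "open" are said of these compounds alone.

Measured in a functional assay on ZR-75-1 cells (Homo sapiens) for inhibition, read by sulforhodamine B assay; a lower number here means a stronger inhibitor of growth, a higher number a weaker inhibitor of growth:
- compound 1 `Fc1ccc(-c2ccc(-c3ccc(-c4nc5ccccc5[nH]4)cc3)cc2)cc1`: 100000 nM
- compound 2 `COc1ccc(-c2ccc(-c3ccc(-c4nc5ccccc5[nH]4)cc3)cc2)cc1`: 35100 nM
- compound 3 `Oc1cccc2[nH]c(-c3ccc(-c4ccc(-c5ccc(F)cc5)cc4)cc3)nc12`: 6320 nM

Of these three, compound 3 has the lowest number, 6320 nM, and so inhibits growth most strongly. Compound 4 `Oc1cccc2[nH]c(-c3ccc(-c4ccc(-c5cccc(Cl)c5)cc4)cc3)nc12` keeps its hydroxy group but carries 3-chlorophenyl in place of 4-fluorophenyl on an aromatic carbon. Adding the hydroxy group was a large step, a 16-fold lower number from compound 1 to compound 3 (1.20 log units; beyond the scatter), but compound 3 and compound 4 both carry it, so it offers no guide here. The closest guide is the replacement of fluoro by methoxy, a 2.8-fold lower number from compound 1 to compound 2 (0.45 log units; beyond the scatter), a modest step. This single example is thin evidence, so only a modest drop is expected, and perhaps none beyond the scatter. The expected change is a 1.4-fold lower number from compound 3 to compound 4 (0.15 log units; within the scatter). The estimate for compound 4 is 4500 nM, with an expected range of 1500 nM to 15000 nM.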

Compound 4, concentration for 50% growth inhibition: 2410 nM
The estimate for compound 4 lay 1.9-fold (0.27 log units) above the measured number; the range from low to high includes it.
By their numbers in this assay, from the lowest: compound 4; then compound 3; then compound 2; then compound 1.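

In this assay, exchanging 4-fluorophenyl for 3-chlorophenyl gives a 2.6-fold lower number from compound 3 to compound 4 (0.42 log units; beyond the scatter) with the hydroxy group held in place. Among these compounds, the end group therefore still moves the number in compounds that carry the hydroxy group, whereas the earlier end-group step was seen only in compounds without it. No measurement shown here explains this step.

As far as these compounds go, both the halogen and its place on the ring change together, so their separate contributions remain open. Whether an amine or a carboxylic acid on the end ring would lower the number further is also unknown.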